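This account rests on a few compounds, and the source may have more. Where it says the series, first, only, none or still open, it means among the compounds named here.

Of the compounds shown here, three of the shared core have been measured in a functional assay for inhibition of sodium/hydrogen exchanger (Oryctolagus cuniculus); a lower number here means a stronger inhibitor, a higher number a weaker inhibitor. Compound 1 `Cc1cc(-c2ccc(Cl)cc2Cl)c(S(C)(=O)=O)cc1C(=O)N=C(N)N` gives 42 nM. Compound 2 `Cc1cc(OC(C)C)c(S(C)(=O)=O)cc1C(=O)N=C(N)N` gives 19 nM. Compound 3 `Cc1cc(Nc2cccc(Cl)c2)c(S(C)(=O)=O)cc1C(=O)N=C(N)N` gives 33 nM. Among these three numbers compound 3 stands in the middle, but its separation from both neighbours is within the scatter: the difference is a 1.3-fold lower number from compound 1 to compound 3 (0.10 log units; within the scatter) on one side and a 1.7-fold higher number from compound 2 to compound 3 (0.24 log units; within the scatter) on the other. Among the compounds with values here, the only step beyond the scatter is a 2.2-fold lower number from compound 1 to compound 2 (0.34 log units; beyond the scatter).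

Compound 4 `Cc1cc(Nc2ncccn2)c(S(C)(=O)=O)cc1C(=O)N=C(N)N` is not yet measured. It differs from compound 3 by pyrimidin-2-yl in place of 3-chlorophenyl on a nitrogen on an aromatic ring. Within the data shown here, no measured step touches the group on that nitrogen; the closest precedent is the replacement at the same aromatic carbon, where a 1.3-fold lower number from compound 1 to compound 3 (0.10 log units; within the scatter) and a 1.7-fold higher number from compound 2 to compound 3 (0.24 log units; within the scatter) both stayed within the scatter even though the entering groups differed considerably from each other. Exchanges of the substituent at this position have therefore moved the inhibitory concentration little, and a change at a nitrogen one bond further out is expected to move it no further.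

Compound 4 is expected to give 35 nM, with a range from 12 nM to 100 nM. The expected step is a 1.1-fold higher number from compound 3 to compound 4 (0.03 log units; within the scatter), which is within the scatter.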

Compound 4, half-maximal inhibitory concentration: 8.3 nM
Compound 4: middle estimate off by 4.2-fold (0.62 log units), on the high side, and the stated range ends above it.
By their numbers in this assay, from the lowest: compound 4; then compounds 2, 3 and 1 (each within the scatter of the next, the first and the last beyond it).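

In this assay the group on the nitrogen turns out to matter: a 4.0-fold lower number from compound 3 to compound 4 (0.60 log units; beyond the scatter) is seen for pyrimidin-2-yl in place of 3-chlorophenyl, a step beyond the scatter, whereas the earlier exchanges leading to compound 3 at the aromatic carbon stayed within it. The (pyrimidin-2-yl)amino group also separates from the other two groups at that aromatic carbon, with a 2.3-fold lower number from compound 2 to compound 4 (0.36 log units; beyond the scatter) against isopropoxy and a 5.1-fold lower number from compound 1 to compound 4 (0.70 log units; beyond the scatter) against 2,4-dichlorophenyl, so compound 4 has the lowest number of the four and its steps to all the others lie beyond the scatter. The change replaces a carbon-only ring carrying chlorine with a ring holding two nitrogens, and no available measurement bears on what lies behind the lower number.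

Open, from the compounds shown here alone, is whether the lower number follows from the ring nitrogens or from the loss of the chlorine, a question that an unsubstituted phenyl or a pyridin-2-yl on the same nitrogen would help separate. Also open, going by these compounds, is whether the nitrogen link is needed at all, which a pyrimidin-2-yloxy group at the same aromatic carbon would test.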